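Swapping a sulfonamide for a difluoroacetamide on a shared core

A few compounds are considered here, and "the series" means these few. Any claim that something is new, unique, unknown or untested is made for them only; others in the source may bear on it.

Among the measured compounds shown here, compound 2 `CS(=O)(=O)NC[C@H]1CN(c2ccc(-n3cc(-c4ccccn4)cn3)c(F)c2)C(=O)O1` shows the higher of the two numbers so far in an ADME assay on HEK293-A cells (Homo sapiens) for cytotoxicity, read by MTT assay, with a stated time of 48 h (on this read-out lower numbers stand for stronger inhibition and higher numbers for weaker inhibition), where compound 2 gives 314 ug/mL. Its nearest neighbour is compound 1 `O=C1CSC(=O)N1C[C@H]1CN(c2ccc(-n3cc(-c4ccccn4)cn3)c(F)c2)C(=O)O1`, which in this assay gives 283 ug/mL; the step of a 1.1-fold higher number from compound 1 to compound 2 (0.05 log units; within the scatter) is within the scatter. Compound 3 `O=C(NC[C@H]1CN(c2ccc(-n3cc(-c4ccccn4)cn3)c(F)c2)C(=O)O1)C(F)F` differs from compound 2 by (difluoromethyl)carbonyl in place of methylsulfonyl on an amine nitrogen. For the measured compounds named here, only the step from compound 1 to compound 2 bears on this, and it changed the same amine-bearing chain without moving the number beyond the scatter. For compound 3 no step beyond the scatter is expected, a 1.0-fold lower number from compound 2 to compound 3 (0.02 log units; within the scatter), giving an estimated 300 ug/mL with a range from 150 ug/mL to 600 ug/mL.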

Compound 3, half-maximal inhibitory concentration: 167 ug/mL
For compound 3 the middle estimate is 1.8-fold (0.25 log units) above the measured one, and the stated range covers the measured number.
By their numbers in this assay, from the lowest: compounds 3, 1 and 2 (each within the scatter of the next).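

In this assay, (difluoromethyl)carbonyl in place of methylsulfonyl on the amine nitrogen gives a 1.9-fold lower number from compound 2 to compound 3 (0.27 log units; within the scatter) and replacing the 2,4-dioxo-1,3-thiazolidin-3-yl group with ((difluoromethyl)carbonyl)amino gives a 1.7-fold lower number from compound 1 to compound 3 (0.23 log units; within the scatter) so a fluorine-bearing carbonyl group now also sits on this chain with no step beyond the scatter. No measurement shown here accounts for these numbers. Still open, going by these compounds, is whether a plain amine, with neither group on this nitrogen, or a longer chain would move the number beyond the scatter.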